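Chalcone-like compound 4 awaits its cytotoxicity value

The source may report more compounds than this note shows. Statements on the series, on what has been measured and on what is new or still open speak of the compounds shown alone.

Values measured in a functional assay on L1210 cells (Mus musculus) for cytotoxicity, read by MTT assay, with a stated time of 24 h (on this read-out lower numbers stand for stronger inhibition and higher numbers for weaker inhibition), so far:
- compound 1 `COc1cc(C(=O)/C=C/c2ccc(Cl)c(Cl)c2)cc(OC)c1OC` gives 44000 nM
- compound 2 `COc1cc(C(=O)/C=C/c2ccc(C)cc2)cc(OC)c1OC` gives 50500 nM
- compound 3 `COc1cc(C(=O)/C=C/c2ccc(F)cc2)cc(OC)c1OC` gives 46500 nM

Compound 3 stands level with both others, since its two steps (a 1.1-fold higher number from compound 1 to compound 3 (0.02 log units; within the scatter)) and (a 1.1-fold lower number from compound 2 to compound 3 (0.04 log units; within the scatter)) stay within the scatter. Compound 4 `COc1cc(C(=O)/C=C/c2cc(Cl)cc(Cl)c2)cc(OC)c1OC` has 3,5-dichlorophenyl in place of 4-fluorophenyl on a double-bonded chain carbon bound to a double-bonded chain carbon. Among the measured compounds shown here, no measured compound carries 3,5-dichlorophenyl. The nearest evidence is the changes at this same place, with the remaining step (a 1.1-fold higher number from compound 1 to compound 2 (0.06 log units; within the scatter)) also within the scatter. In this assay no step beyond the scatter is therefore expected (a 1.1-fold lower number from compound 3 to compound 4 (0.02 log units; within the scatter)). The estimated value for compound 4 is 44000 nM (expected range 26000 nM to 72000 nM).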

Compound 4, half-maximal inhibitory concentration: 44000 nM
Estimate against measurement, compound 4: no gap at the digits printed; measured number inside the range.
By their numbers in this assay, from the lowest: compounds 1, 4, 3 and 2 (each within the scatter of the next).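

In this assay, 3,5-dichlorophenyl on this chain carbon stays level with 4-fluorophenyl (a 1.1-fold lower number from compound 3 to compound 4 (0.02 log units; within the scatter)) and 4-methylphenyl (a 1.1-fold lower number from compound 2 to compound 4 (0.06 log units; within the scatter)). The two dichlorophenyl patterns also cannot be told apart here (no change at the digits printed from compound 1 to compound 4 (within the scatter)), so across these four compounds, neither the chlorine arrangement nor the aryl substituents tried separate the values. Nothing available explains this flat result.

As far as these compounds go, whether any group at this place can move the number beyond the scatter stays open, for instance a phenyl ring carrying an amine or a carboxylic acid. From the compounds shown here alone, the effect of changes to the shared core also remains unknown.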